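Acyl variation on the shared amide series

The source may report more compounds than this note shows. Statements on the series, on what has been measured and on what is new or still open speak of the compounds shown alone.

Measured so far in a functional assay on KYSE-450 cells (Homo sapiens) for inhibition, read by MTT assay, with a stated time of 48 h; on this read-out higher numbers stand for weaker inhibition and lower numbers for stronger inhibition:
- compound 1 `C/C=C/C(=O)N(Cc1cccc(O)c1)c1cc(OC)c(OC)c(OC)c1` gives 14700 nM
- compound 2 `C/C=C/C=C/C(=O)N(Cc1ccc(OC)c(O)c1)c1cc(OC)c(OC)c(OC)c1` gives 180 nM
- compound 3 `COc1ccc(CNc2cc(OC)c(OC)c(OC)c2)cc1Br` gives 39800 nM

Compound 2 holds the lowest number of the three, and its gaps to compound 1 and to compound 3 both lie beyond the usual scatter, so it is the most potent compound measured here. Within the data shown here, no pair among the measured compounds differs in only one place, so no single step can be read off; compound 1 and compound 3 each change more than the acyl group relative to compound 2, and their values say only that both are far weaker.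

Compound 4 `COc1ccc(CN(C(=O)C=C(C)C)c2cc(OC)c(OC)c(OC)c2)cc1O` keeps everything of compound 2 except the acyl chain: 2-methylprop-1-en-1-yl in place of penta-1,3-dien-1-yl on a carbonyl carbon

Nothing measured isolates the effect of this chain. Compound 1, which carries a shorter chain on the same carbonyl, is much weaker than compound 2, but it also differs in the phenol pattern, so it is only a rough pointer. The step from compound 2 to compound 4 is expected to run upward, toward weaker inhibition, by more than the scatter: a 6.7-fold higher number from compound 2 to compound 4 (0.82 log units; beyond the scatter). Compound 4 is therefore estimated at 1200 nM in this assay, within a range of 250 nM to 8000 nM.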

Compound 4, half-maximal inhibitory concentration: 280 nM
Compound 4: middle estimate off by 4.3-fold (0.63 log units), on the high side; the measured number falls inside the stated range.
By their numbers in this assay, from the lowest: compounds 2 and 4 (each within the scatter of the next); then compound 1; then compound 3.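

In this assay, among these compounds, the exchange of penta-1,3-dien-1-yl for 2-methylprop-1-en-1-yl on a carbonyl carbon bonded to the amide-type nitrogen is the first change that can be read on its own, and it gives a 1.6-fold higher number from compound 2 to compound 4 (0.19 log units; within the scatter). With everything else held, this position therefore accepts either chain within the usual scatter, so going from 5 heavy atoms and 2 double bonds outside aromatic rings to 4 heavy atoms and 1 such double bond leaves no readable difference in this assay. No independent measurement bears on this result, which stands as an observation on this one pair only.

On these data alone, whether the same holds for a longer chain such as n-hexyl, for a saturated chain such as n-butyl, or for a phenyl ring or a carboxylic acid on the same carbonyl remains open. Among the compounds shown here, also open is how much of the distance of compound 1 from this pair belongs to its acyl chain and how much to its phenol pattern, as no single-place step connects compound 1 to either compound.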